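The compounds below may be only part of what the source reports. "The series", "measured", "known", "first", "only" and "open" are said of these compounds alone.

Of the compounds shown here, three have so far been measured in a functional assay on MDA-MB-231 cells (Homo sapiens) for inhibition, read by MTT assay, with a stated time of 72 h, tested at 20 uM; a lower number here means less inhibition, a higher number more inhibition at the concentration tested (going by the name of the read-out). Compound 1 `c1cc(N2CCCCC2)nc(Nc2ccc(Oc3ncnc4sccc34)cc2)n1` gives 40.4% in this assay. Compound 3 `CN(c1ccc(Oc2ncnc3sccc23)cc1)c1nccc(N2CCCCC2)n1` gives 29.3% in this assay. Compound 2 `CN(c1ccc(Oc2ncnc3ccsc23)cc1)c1nccc(N2CCc3ccccc3C2)n1` gives 30.2% in this assay; compound 2 and compound 3 lie within the usual scatter of each other, whereas compound 1 gives the highest number of the three.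

Compound 1 differs from compound 3 in one place: hydrogen in place of methyl on a nitrogen on an aromatic ring. The step of a number 11.1 percentage points higher from compound 3 to compound 1 (beyond the scatter) is modest but beyond the scatter.

Compound 4 `c1ccc2c(c1)CCN(c1ccnc(Nc3ccc(Oc4ncnc5ccsc45)cc3)n1)C2` has not yet been measured. It stands to compound 2 as compound 1 stands to compound 3: hydrogen in place of methyl on a nitrogen on an aromatic ring. The surroundings of the place are described in the same words in both cases, so this is the same change, made twice among these compounds. Compound 2 and compound 3, however, carry different cores, and the difference between the two cores is not broken down here; how fully the earlier step carries over to the new core is therefore an open question.

With nothing else to go on, the account expects a step of about the same size as a number 11.1 percentage points higher from compound 3 to compound 1 (beyond the scatter), that is, an expected a number 10.8 percentage points higher from compound 2 to compound 4 (beyond the scatter). This expectation rests on compound 2 giving 30.2% and on the step of a number 11.1 percentage points higher from compound 3 to compound 1 (beyond the scatter). Compound 4 is accordingly estimated at 41% in this assay, expected to fall between 29% and 53%.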

Compound 4, a percentage reported as inhibition, at one concentration (the size of the read-out at that concentration, not a potency): 15.4%
Beside the measured number, compound 4's estimate is 25.6 percentage points above it; measured number below the stated range.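

In this assay, hydrogen in place of methyl on the nitrogen does not behave as one transferable step, since on the core of compound 2 it gives a number 14.8 percentage points lower from compound 2 to compound 4 (beyond the scatter), whereas on the core of compound 3 it gives a number 11.1 percentage points higher from compound 3 to compound 1 (beyond the scatter). The two results point in opposite directions, so the step measured on one core could not be carried to the other, not even in its sign: the same change on two cores in this assay, a number 11.1 percentage points higher (beyond the scatter) from compound 3 to compound 1 and a number 14.8 percentage points lower (beyond the scatter) from compound 2 to compound 4, 25.9 percentage points apart, beyond the scatter of two such steps. Among the compounds shown here, this shows that the effect of this change depends on the core in these two pairs, but it does not show which feature of the core is responsible, and with only two pairs, each read at a single concentration, it establishes no rule for any other core.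

No pair shown alters one part of the core alone, so which part decides the direction of the step remains open. Also open, on these data alone, is how an ethyl or an acetyl group on that same nitrogen would read in this assay on either core, and whether it would follow the methyl compounds or the hydrogen compounds.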